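From butylamino to thiophen-2-yl on the sulfonyl sulfur

The source may hold more compounds than are shown below. What is called first, only, known or untested is meant among the compounds shown, and "the series" means these compounds.

Values in a functional assay for inhibition, with Homo sapiens as the target; on this read-out higher numbers stand for weaker inhibition and lower numbers for stronger inhibition:
- compound 1 `CCCCS(=O)(=O)N[C@@H](CNC(=O)c1ccc2c(c1)C(=O)N(CCC1CCNCC1)C2)C(=O)O`: 14 nM; 9 nM (2 entries)
- compound 2 `CCCCCS(=O)(=O)N[C@@H](CNC(=O)c1ccc2c(c1)C(=O)N(CCC1CCNCC1)C2)C(=O)O`: 9 nM
- compound 3 `CCCCNS(=O)(=O)N[C@@H](CNC(=O)c1ccc2c(c1)C(=O)N(CCC1CCNCC1)C2)C(=O)O`: 19 nM

Of the two compounds with a single number, compound 3 has the higher one, 19 nM. Compound 1 has no single number, as shown by the several entries of compound 1 in this assay, 14 nM; 9 nM (2 entries).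

The next compound is compound 4 `O=C(NC[C@H](NS(=O)(=O)c1cccs1)C(=O)O)c1ccc2c(c1)C(=O)N(CCC1CCNCC1)C2`. The change is thiophen-2-yl in place of butylamino on a sulfonyl sulfur, with thiophen-2-yl in place of butylamino on a sulfonyl sulfur.

Among the compounds with values here, one measured step bears on this change, since it alters the same sulfonyl sulfur substituent: a 2.1-fold higher number from compound 2 to compound 3 (0.32 log units; beyond the scatter). That step is modest and only just beyond the scatter. Within the data shown here, no compound with an aromatic ring at this place has a measured value yet, so it gives a guide to size but little guide to direction. In this assay, a modest step at most is therefore expected, leaning towards a lower number and most likely not beyond the scatter.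

The estimated step is a 1.4-fold lower number from compound 3 to compound 4 (0.13 log units; within the scatter).

For compound 4, the estimate is 14 nM, with an expected range of 6 nM to 35 nM.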

Compound 4, half-maximal inhibitory concentration: 7 nM
Estimate against measurement, compound 4: 2.0-fold (0.30 log units) above, within the range that was stated.
By their numbers in this assay, from the lowest: compounds 4 and 2 (each within the scatter of the next); then compound 3.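

In this assay, an aromatic ring on the sulfonyl sulfur holds up against both open chains, and replacing butylamino with thiophen-2-yl gives a 2.7-fold lower number from compound 3 to compound 4 (0.43 log units; beyond the scatter). Replacing pentyl with thiophen-2-yl gives a 1.3-fold lower number from compound 2 to compound 4 (0.11 log units; within the scatter), so the ring and the pentyl chain are not told apart at this place, and butylamino is the one substituent with a single number that stands beyond the scatter from the others. Compound 1 has no single number and stays outside this ordering: the several entries of compound 1 in this assay, 14 nM; 9 nM (2 entries)

Only one ring is shown here, so it remains open whether phenyl or a thiophen-2-yl carrying a chlorine would read the same. On these data alone, it is also open whether the higher number of compound 3 goes with the sulfamoyl nitrogen as such, which a shorter alkylamino such as propylamino would help to test.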